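Methylamino to isopropyl: next step in the series

The source may hold more compounds than are shown below. What is called first, only, known or untested is meant among the compounds shown, and "the series" means these compounds.

Among the compounds with values here, in a physicochemical assay for lipophilicity, read by HPLC, at pH 7.5 (a higher number here means a more lipophilic compound, a lower number a more polar compound), compound 1 `CC[C@@H](Nc1c(C#N)c(-c2ccc(-c3ccncc3C)cc2)nc2cnccc12)C(N)=O` gives 2 and compound 2 `CC[C@@H](Nc1c(C#N)c(-c2ccc(-c3ccccc3NC)cc2)nc2cnccc12)C(N)=O` gives 2.5, the higher of the two numbers so far. Within the data shown here, the only measured step is a number 0.50 log units higher from compound 1 to compound 2 (beyond the scatter), with 2-(methylamino)phenyl in place of 3-methylpyridin-4-yl on an aromatic carbon.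

Compound 3 `CC[C@@H](Nc1c(C#N)c(-c2ccc(-c3ccccc3C(C)C)cc2)nc2cnccc12)C(N)=O` differs from compound 2 at that same substituent: isopropyl in place of methylamino on an aromatic carbon. This puts isopropyl in place of methylamino on an aromatic carbon, ortho to a large group. Among the measured compounds shown here, no measured step makes this exact exchange, so a number 0.50 log units higher from compound 1 to compound 2 (beyond the scatter) is the only size guide, and an indirect one. The change removes the counted hydrogen-bond donor and acceptor and adds a carbon-only group. In this assay, the expected step is a number 0.60 log units higher from compound 2 to compound 3 (beyond the scatter), upward and somewhat larger than the measured one. For compound 3 the estimate is 3.1, with an expected range of 2.7 to 3.6.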

Compound 3, distribution coefficient: 3.5
Compound 3: the middle estimate sits 0.40 log units below what was measured; measured number inside the range.
By their numbers in this assay, from the lowest: compound 1; then compound 2; then compound 3.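

With the carbon-only aromatic ring kept, isopropyl in place of methylamino gives a number 1.00 log units higher from compound 2 to compound 3 (beyond the scatter) in this assay, so the substituent on that ring alone shifts the number, with no change to the ring itself. Within the data shown here, measured from 3-methylpyridin-4-yl, 2-isopropylphenyl gives a number 1.50 log units higher from compound 1 to compound 3 (beyond the scatter) as the largest step among the three compounds, and no compound here goes against the order compound 1, compound 2, compound 3. Nothing available here explains the size of either step.

On these data alone, whether the number keeps rising with a tert-butyl group or a longer alkyl chain in this place remains open, as does the reading for a primary amine or a carboxylic acid there. Three compounds also cannot show whether the isopropyl for methylamino exchange gives a step of similar size on another core.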